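A few compounds are considered here, and "the series" means these few. Any claim that something is new, unique, unknown or untested is made for them only; others in the source may bear on it.

Measured in an assay on isolated protein for binding affinity to leukotriene B4 receptor 1 (Homo sapiens), tested at 1 uM; a higher number here means more inhibition at the concentration tested (going by the name of the read-out), a lower number less inhibition:
compound 1 `CCc1cc(C(C)=O)c(O)cc1OCCCC(C)(C)C#N` — 46%
compound 2 `CCc1cc(C(C)=O)c(O)cc1OCCCCC(C)(C)C#N` — 30%
compound 3 `CCc1cc(C(C)=O)c(O)cc1OCCCCCCC(C)(C)C#N` — 30%

Compound 3 stands level with compound 2, the two together the lowest of the three numbers; against compound 1 it reads a number 16 percentage points lower from compound 1 to compound 3 (beyond the scatter), and no change at the digits printed from compound 2 to compound 3 (within the scatter).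

Compound 4 `CCc1cc(C(C)=O)c(O)cc1OCCCC(C)(C)C(=O)O` differs from compound 3 by 1-carboxy-1-methylethyl in place of 4-cyano-4-methylpentyl on a saturated chain carbon, three bonds along the chain from an oxygen on an aromatic ring. The chain thus returns to the length found in compound 1, and the nitrile gives way to a carboxylic acid. Among the measured compounds shown here, the chain part is covered by the steps of a number 16 percentage points lower from compound 1 to compound 2 (beyond the scatter) and a number 16 percentage points lower from compound 1 to compound 3 (beyond the scatter), both modest; the nitrile-to-acid part has no measured counterpart here. An upward step in this assay is therefore expected, roughly undoing a number 16 percentage points lower from compound 1 to compound 3 (beyond the scatter), with wide uncertainty. Compound 4 is expected at 44%, range 20% to 68%, a step of a number 14 percentage points higher from compound 3 to compound 4 (beyond the scatter).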

Compound 4, a percentage reported as inhibition, at one concentration (the size of the read-out at that concentration, not a potency): 43%
Compound 4: middle estimate off by 1 percentage points, on the high side; low and high end bracket the measured number.
By their numbers in this assay, from the lowest: compounds 2 and 3 (each within the scatter of the next); then compounds 4 and 1 (each within the scatter of the next).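

At the place three bonds along the chain from the oxygen on the aromatic ring, 1-carboxy-1-methylethyl and 1-cyano-1-methylethyl read alike in this assay (a number 3 percentage points lower from compound 1 to compound 4 (within the scatter)), so this assay does not separate carboxy from cyano on this chain. 1-Carboxy-1-methylethyl also stands clear of the longer nitrile chains (a number 13 percentage points higher from compound 2 to compound 4 (beyond the scatter)) (a number 13 percentage points higher from compound 3 to compound 4 (beyond the scatter)). No measured evidence bears on these readings.

On these data alone, whether a longer chain ending in a carboxylic acid, such as 4-carboxy-4-methylpentyl, falls as the nitrile chains do remains open. So does how a primary amide reads at this place.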